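A few compounds are considered here, and "the series" means these few. Any claim that something is new, unique, unknown or untested is made for them only; others in the source may bear on it.

Compound 2 `NC(=O)Cc1cc(=O)oc2cc(OCc3ccccc3)ccc12` is one of two compounds tested in an assay for inhibition of Amine oxidase [flavin-containing] B (Rattus norvegicus) (on this read-out higher numbers stand for weaker inhibition and lower numbers for stronger inhibition), where compound 2 gives 200 nM. Compound 1 `NC(=O)[C@@H]1CCCN1c1cc(=O)oc2cc(OCc3ccccc3)ccc12` gives 16100 nM in this assay, so compound 2 holds the lower of the two numbers. For the measured compounds named here, the only measured step, an 81-fold lower number from compound 1 to compound 2 (1.91 log units; beyond the scatter), alters a different part of the molecule, so no measured step speaks directly to the next change. Compound 3 `CNCc1cc(=O)oc2cc(OCc3ccccc3)ccc12` differs from compound 2 by methylamino in place of carbamoyl on a saturated chain carbon bound to an aromatic carbon. For compound 3 a moderate weakening is expected: a 7.5-fold higher number from compound 2 to compound 3 (0.88 log units; beyond the scatter). Compound 3 is therefore estimated at 1500 nM in this assay, within 300 nM to 8000 nM.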

Compound 3, half-maximal inhibitory concentration: 28 nM
Beside the measured number, compound 3's estimate is 54-fold (1.73 log units) above it; measured number below the stated range.
By their numbers in this assay, from the lowest: compound 3; then compound 2; then compound 1.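

In this assay, the carbamoyl on this saturated chain carbon is not needed for a low number: methylamino in its place gives a 7.1-fold lower number from compound 2 to compound 3 (0.85 log units; beyond the scatter). On the aromatic carbon, (methylamino)methyl in place of 2-carbamoylpyrrolidin-1-yl gives a 580-fold lower number from compound 1 to compound 3 (2.76 log units; beyond the scatter), the largest step among these three compounds. No supporting evidence is available to explain either step.

As far as these compounds go, whether a primary amine, a dimethylamino group or a longer chain carrying methylamino would give a lower or higher number remains open.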